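Replacing the Amine End with a (Carboxymethyl)amino Group

A few compounds are considered here, and "the series" means these few. Any claim that something is new, unique, unknown or untested is made for them only; others in the source may bear on it.

Compound 1: `CC(=O)Oc1ccc(C(=O)Nc2cc3ccc(OCC4CCN(C)C4)c(C)c3oc2=O)cc1CC=C(C)C`, 880 nM
Compound 2: `CCN(C)CCCOc1ccc2cc(NC(=O)c3ccc(O)c(CC=C(C)C)c3)c(=O)oc2c1C`, 730 nM
Compound 3: `CC(C)=CCc1cc(C(=O)Nc2cc3ccc(OCCCN(C)C(C)C)c(C)c3oc2=O)ccc1O`, 570 nM

In a functional assay on SK-BR-3 cells (Homo sapiens) for antiproliferative activity (on this read-out higher numbers stand for weaker inhibition and lower numbers for stronger inhibition), compound 2 gives 730 nM, the second highest of the three numbers; its nearest neighbour is compound 1 with 880 nM and its furthest is compound 3 with 570 nM, and both gaps lie within the scatter, so the three measured compounds cannot be told apart on this assay.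

Compound 4, `CC(C)=CCc1cc(C(=O)Nc2cc3ccc(OCCCNCC(=O)O)c(C)c3oc2=O)ccc1O`, differs from compound 2 at the amine end of the side chain: (carboxymethyl)amino in place of ethyl(methyl)amino on a saturated chain carbon, three bonds along the chain from an oxygen on an aromatic ring.

Among the measured compounds shown here, only one measured step touches this part of the molecule, and it is a much smaller alteration of the same amine: a 1.3-fold lower number from compound 2 to compound 3 (0.11 log units; within the scatter). For the measured compounds named here, no measured compound carries a (carboxymethyl)amino group or any comparable group, so nothing in the data shows how such a replacement moves the number. Given that the one relevant step was within the scatter, the expected change is modest but uncertain; a slightly higher number, meaning weaker inhibition, is the estimate, as a 2.1-fold higher number from compound 2 to compound 4 (0.31 log units; beyond the scatter). For compound 4 the expected value is therefore 1500 nM, with a range from 500 nM to 5000 nM.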

Compound 4, half-maximal inhibitory concentration: 7570 nM
For compound 4 the middle estimate is 5.0-fold (0.70 log units) below the measured one, outside the stated range (above it).
By their numbers in this assay, from the lowest: compounds 3, 2 and 1 (each within the scatter of the next); then compound 4.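

In this assay, among the compounds shown here, the swap of ethyl(methyl)amino for (carboxymethyl)amino gives a 10-fold higher number from compound 2 to compound 4 (1.02 log units; beyond the scatter) and marks a clear loss of inhibition, so the amine end of the side chain is not as forgiving as the earlier compounds suggested. The same conclusion comes from the other available starting point, with a 13-fold higher number from compound 3 to compound 4 (1.12 log units; beyond the scatter) on replacing isopropyl(methyl)amino with the same group. For the compounds shown here, the only earlier change at this place, a far smaller edit of the amine, gave a 1.3-fold lower number from compound 2 to compound 3 (0.11 log units; within the scatter) and so showed no effect, whereas these two large steps show that what sits at the end of the chain can move the number a long way.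

The compounds shown leave open whether the carboxylic acid itself accounts for the rise or whether losing both alkyl groups on the nitrogen contributes, a question that a methylamino end or the methyl ester of the same acid would help to separate. No measurement shown here explains why the number rises at this position.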